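The compounds below may be only part of what the source reports. "The series", "measured", "known", "first", "only" and "open" are said of these compounds alone.

Working notes on the series in a functional assay on SF-268 cells (Homo sapiens) for cytotoxicity, read by MTT assay, with a stated time of 3 days; a higher number here means a weaker inhibitor, a lower number a stronger inhibitor. Two compounds with measured values share the core: compound 1 `N#Cc1c(Nc2nccs2)nc(SCc2nc3ccccc3[nH]2)nc1-c1ccccc1` gives 2.55 nM, and compound 2 `N#Cc1c(NNC(N)=S)nc(SCc2nc3ccccc3[nH]2)nc1-c1ccccc1` gives 3.37 nM. Among the measured compounds shown here, compound 2 therefore stands within the scatter of compound 1, its only measured neighbour. Compound 3 `N#Cc1c(NC(N)=S)nc(SCc2nc3ccccc3[nH]2)nc1-c1ccccc1` differs from compound 2 in a single place: a group of 3 heavy atoms (1 carbon, 1 nitrogen, 1 sulfur; no ring) in place of a group of 4 heavy atoms (1 carbon, 2 nitrogen, 1 sulfur; no ring), on a nitrogen on an aromatic ring. For the measured compounds named here, one measured step bears on this change, at the same place on the core: a 1.3-fold higher number from compound 1 to compound 2 (0.12 log units; within the scatter). That exchange of groups left the number within the scatter, although a single step is thin support. No step beyond the scatter is therefore expected in this assay, and no direction can be assigned. The expected result is a 1.1-fold lower number from compound 2 to compound 3 (0.05 log units; within the scatter). For compound 3 the estimated value is 3 nM, with an expected range of 1.2 nM to 7.5 nM.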

Compound 3, half-maximal inhibitory concentration: 3.37 nM
The estimate for compound 3 lay 1.1-fold (0.05 log units) below the measured number; measured number inside the range.
By their numbers in this assay, from the lowest: compounds 1, 2 and 3 (each within the scatter of the next).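

In this assay, a second change on a nitrogen on an aromatic ring again leaves the number within the scatter (no change at the digits printed from compound 2 to compound 3 (within the scatter)), with 1 hydrogen-bond donor entering where 2 hydrogen-bond donors leave. The group without a ring also stays within the scatter when set against the five-membered aromatic ring group (a 1.3-fold higher number from compound 1 to compound 3 (0.12 log units; within the scatter)), so all three groups shown at this place give numbers within the scatter of one another. No measurement at hand explains this flat picture.

From the compounds shown here alone, whether it holds beyond these three groups stays open, for example with an acetyl group or a longer alkyl chain at this nitrogen. All three compounds also keep the rest of the shared core unchanged, so the compounds shown cannot tell whether the flat picture would survive a change elsewhere.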